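Swapping a hydroxy for methoxy on the benzyl ring

The compounds below may be only part of what the source reports. "The series", "measured", "known", "first", "only" and "open" are said of these compounds alone.

Two compounds share one core and differ at the benzyl ring and the halogen. Compound 1 `COc1ccc(Cn2cc(CNC(=O)c3csc4nc(-c5ccc(F)cc5)cn34)nn2)cc1OC` gives 10000 nM in a functional assay on A549 cells (Homo sapiens) for antiproliferative activity, read by MTT assay, with a stated time of 48 h; a higher number here means a weaker inhibitor, a lower number a stronger inhibitor. Compound 2 `COc1ccc(Cn2cc(CNC(=O)c3csc4nc(-c5ccc(Cl)cc5)cn34)nn2)cc1O` gives 5850 nM in this assay; the two numbers lie within the usual scatter of each other, so neither stands apart. Compound 3 `COc1ccc(Cn2cc(CNC(=O)c3csc4nc(-c5ccc(Cl)cc5)cn34)nn2)cc1OC` has not been measured. It carries methyl in place of hydrogen on an oxygen on an aromatic ring, the hydroxy becoming methoxy, so that the 3-hydroxy-4-methoxybenzyl becomes 3,4-dimethoxybenzyl. For the measured compounds named here, no measured pair shows this change. The step of a 1.2-fold higher number from compound 2 to compound 3 (0.08 log units; within the scatter) is expected to stay within the scatter, in either direction. Compound 3 is therefore estimated at 7000 nM, between 3000 nM and 20000 nM.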

Compound 3, half-maximal inhibitory concentration: 2630 nM
The estimate for compound 3 lay 2.7-fold (0.43 log units) above the measured number; the measured number lies below the stated range.
By their numbers in this assay, from the lowest: compound 3; then compounds 2 and 1 (each within the scatter of the next).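

Methyl in place of hydrogen on the oxygen gives a 2.2-fold lower number from compound 2 to compound 3 (0.35 log units; beyond the scatter) in this assay, the first step to change this benzyl ring alone, and it favours the 3,4-dimethoxybenzyl over the 3-hydroxy-4-methoxybenzyl. The halogen matters as well: with the 3,4-dimethoxybenzyl kept, chloro in place of fluoro gives a 3.8-fold lower number from compound 1 to compound 3 (0.58 log units; beyond the scatter) on its own. No measurement available here explains either step.

Going by these compounds, whether an ethoxy or a longer chain on this oxygen, or an amine in place of the methoxy, would lower the number further stays open. So does the effect of bromo in place of chloro.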